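Benzyloxy to diethylamino on the carbonyl carbon

The source may report more compounds than this note shows. Statements on the series, on what has been measured and on what is new or still open speak of the compounds shown alone.

In a functional assay on A 172 cells (Homo sapiens) for cytotoxicity, read by colorimetric assay and MTT assay (on this read-out higher numbers stand for weaker inhibition and lower numbers for stronger inhibition), the measured compounds stand as follows
- compound 1 `COC(=O)CCn1c(=O)c(-c2ccc(OC)cc2)cc2c(OC)cc(OC)cc21` gives 10000 nM
- compound 2 `COc1ccc(-c2cc3c(OC)cc(OC)cc3n(CCC(=O)OCc3ccccc3)c2=O)cc1` gives 10000 nM

Level with compound 1, compound 2 gives 10000 nM as its value. Compound 3 `CCN(CC)C(=O)CCn1c(=O)c(-c2ccc(OC)cc2)cc2c(OC)cc(OC)cc21` carries diethylamino in place of benzyloxy on a carbonyl carbon. Among the compounds with values here, the only measured step of no change at the digits printed from compound 1 to compound 2 (within the scatter) stayed within the scatter and involved neither diethylamino nor any replacement of benzyloxy, so it bears only weakly on this change. No step beyond the scatter is therefore expected in this assay and the expected step of no change at the digits printed from compound 2 to compound 3 (within the scatter) has no direction. For compound 3 the estimated value is 10000 nM with an expected range from 4000 nM to 20000 nM for now.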

Compound 3, half-maximal inhibitory concentration: 10000 nM
Beside the measured number, compound 3's estimate shows no gap at the digits printed; low and high end bracket the measured number.
By their numbers in this assay, from the lowest: compounds 1, 2 and 3 (each within the scatter of the next).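

In this assay, diethylamino on the carbonyl carbon gives no change at the digits printed from compound 2 to compound 3 (within the scatter), and the same group in place of methoxy gives no change at the digits printed from compound 1 to compound 3 (within the scatter). This position has now taken a nitrogen-linked group without a ring as well as the two oxygen-linked groups, and the three compounds remain level. No measured evidence accounts for this. From the compounds shown here alone, whether a carboxylic acid on this carbonyl carbon, or a longer chain leading to it, would separate from these compounds remains open.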